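Phenyl in place of thiophen-3-yl on the shared core

This account rests on a few compounds, and the source may have more. Where it says the series, first, only, none or still open, it means among the compounds named here.

Compound 1 `O=C(Nc1cccc(-c2ccsc2)c1)C(Cl)Cl` carries thiophen-3-yl on the shared core. In a functional assay on KB 3-1 cells (Homo sapiens) for cytotoxicity, read by MTT assay, with a stated time of 68 h (a higher number here means a weaker inhibitor, a lower number a stronger inhibitor), compound 1 gives > 50000 nM, which is a limit of the assay and not a number. Compound 2 `O=C(Nc1cccc(-c2ccoc2)c1)C(Cl)Cl` carries furan-3-yl in its place. In this assay compound 2 gives > 50000 nM, again a limit. Compound 3 `COc1ccc(-c2cccc(NC(=O)C(Cl)Cl)c2)cc1` carries a methoxy-bearing phenyl there. In this assay compound 3 gives > 50000 nM, also a limit. Compound 1 thus stands at the limit together with every other measured member of the series: the limit of > 50000 nM in this assay, at which 3 of the 3 values shown sit. For the measured compounds named here, the single step between measured compounds, a step that the two limits leave unreadable from compound 1 to compound 2, is accordingly of unreadable size.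

Compound 4 `O=C(Nc1cccc(-c2ccccc2)c1)C(Cl)Cl` is not yet measured. It differs from compound 1 as follows: phenyl in place of thiophen-3-yl on an aromatic carbon. Going by the values given here, no measured step reads on this change; the step from thiophen-3-yl to furan-3-yl is unreadable, and compound 3, with methoxy on its phenyl, sits at the limit as well. The expectation in this assay is therefore no step beyond the scatter, with compound 4 most likely reported as a limit once more. The estimate for compound 4 in this assay is 50000 nM, in the range 20000 nM to 150000 nM. The step of a number no higher from compound 1 to compound 4 (the limit leaves the size open) is expected to be none beyond the scatter.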

Compound 4, half-maximal inhibitory concentration: 46800 nM
Compound 4: middle estimate off by 1.1-fold (0.03 log units), on the high side, within the range that was stated.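

In this assay, for the compounds shown here, compound 4 gives 46800 nM, the first reading that is a number and not a limit, so this position on the shared core now has one measured value, with unsubstituted phenyl in place. The three new steps are open-ended, and each has a floor within the scatter: an at least 1.0-fold lower number from compound 1 to compound 4 (0.02 log units; that floor lies within the scatter) for phenyl in place of thiophen-3-yl, an at least 1.0-fold lower number from compound 2 to compound 4 (0.02 log units; that floor lies within the scatter) for phenyl in place of furan-3-yl, and an at least 1.0-fold lower number from compound 3 to compound 4 (0.02 log units; that floor lies within the scatter) for hydrogen in place of methoxy. None of these changes is therefore shown to move the value beyond the scatter, though the true size of each step stays unknown, and the series remains almost wholly at the assay's ceiling: the limit of > 50000 nM in this assay, at which 3 of the 4 values shown sit.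

Still open, as far as these compounds go, is whether any group at this position gives a value well inside the measurable range, for example an amine or a carboxylic acid on the phenyl of compound 4. Also open, from the compounds shown here alone, is how far the readings of compound 1, compound 2 and compound 3 lie past their limits, so the order among the aromatic groups at this position cannot be stated.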